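A few compounds are considered here, and "the series" means these few. Any claim that something is new, unique, unknown or untested is made for them only; others in the source may bear on it.

Measured compounds:
compound 1 `ClC1=C(c2nnc(-c3ccccc3)o2)CCCc2ccccc21`: 3220 nM
compound 2 `Cc1ccc(-c2nnc(C3=C(Cl)c4ccccc4CCC3)o2)cc1`: 79 nM
compound 3 `Cc1cc2c(cc1C)C(Cl)=C(c1nnc(-c3ccccc3)o1)CCC2`: 4680 nM

In a functional assay on HeLa cells (Homo sapiens) for antiproliferative activity, read by sulforhodamine B assay, with a stated time of 48 h (on this read-out lower numbers stand for stronger inhibition of growth and higher numbers for weaker inhibition of growth), compound 1 gives 3220 nM and compound 2 gives 79 nM. The change between them is methyl in place of hydrogen on an aromatic carbon, and it produced a 41-fold lower number from compound 1 to compound 2 (1.61 log units; beyond the scatter). Compound 3 differs from compound 1 in its core; how the two cores differ is not broken down here. In this assay compound 3 gives 4680 nM, which sits within the scatter of the number for compound 1.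

Compound 4 `Cc1ccc(-c2nnc(C3=C(Cl)c4cc(C)c(C)cc4CCC3)o2)cc1` is not yet measured. Compound 4 arises from compound 3 by methyl in place of hydrogen on an aromatic carbon, the same change that turns compound 1 into compound 2, with the same surroundings of the place in both cases. Within the data shown here, the single precedent is the large step from compound 1 to compound 2, and the cores of compound 1 and compound 3 give numbers close to one another, so the expectation is that the step from compound 3 to compound 4 will be of similar direction and roughly similar size, tempered slightly because a 41-fold lower number from compound 1 to compound 2 (1.61 log units; beyond the scatter) rests on one pair only; the expected step is a 31-fold lower number from compound 3 to compound 4 (1.49 log units; beyond the scatter). The estimate for compound 4 in this assay is 150 nM, with a range from 40 nM to 700 nM.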

Compound 4, concentration for 50% growth inhibition: 679 nM
Compound 4: middle estimate off by 4.5-fold (0.66 log units), on the low side, within the range that was stated.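

In this assay, phenyl to 4-methylphenyl on the core of compound 3 gives a 6.9-fold lower number from compound 3 to compound 4 (0.84 log units; beyond the scatter), so the methyl again lowers the number, as it did on the core of compound 1. Among these compounds, the direction carries from one core to the other, but the size does not: the same change on two cores in this assay, a 41-fold lower number (1.61 log units; beyond the scatter) from compound 1 to compound 2 and a 6.9-fold lower number (0.84 log units; beyond the scatter) from compound 3 to compound 4, 5.9-fold (0.77 log units) apart, beyond the scatter of two such steps With only two pairs, this shows that the step measured on one core cannot be used as a size estimate for the other; it does not show what sets the size of the step, or how the change would behave on any further core.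

As far as these compounds go, it remains open whether an ethyl, a methoxy, an amine or a carboxylic acid in the same place on the aromatic ring would follow the methyl in direction on these two cores. From the compounds shown here alone, it is equally open whether the gap in step size between the two cores would hold for such groups or belongs to the methyl alone.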